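This account rests on a few compounds, and the source may have more. Where it says the series, first, only, none or still open, it means among the compounds named here.

Compound 1 `CC(C)CCNCCN(C(=O)[C@@H]1C[C@H]1c1ccccc1)c1ccc(-c2ccccc2)cc1`: 5.1 nM
Compound 2 `CC(C)C[C@H](N)CN(C(=O)[C@@H]1C[C@H]1c1ccccc1)c1ccc(-c2ccccc2Cl)cc1`: 3800 nM
Compound 3 `CCc1ccc(-c2ccc(N(C[C@@H](N)[C@@H](C)CC)C(=O)[C@@H]3C[C@H]3c3ccccc3)cc2)cc1`: 44 nM

In a functional assay for agonist activity at G protein-coupled receptor 88 (Homo sapiens), read by HTRF and cAMP accumulation (a lower number here means that less compound is needed, a higher number that more compound is needed for the effect), compound 3 gives 44 nM, the second highest of the three numbers. Compound 1 gives 5.1 nM, a lower number beyond the scatter, and compound 2 gives 3800 nM, a higher number beyond the scatter. Compound 4 `CC[C@H](C)[C@H](N)CN(C(=O)[C@@H]1C[C@H]1c1ccccc1)c1ccc(-c2ccc(NC(C)=O)cc2)cc1` has not been measured. It differs from compound 3 in one place: acetamido in place of ethyl on an aromatic carbon. Within the data shown here, no step between measured compounds isolates a change of this kind, and compounds 1 and 2 differ from compound 3 in more than this one place, so there is no direct guide. The step of a 1.6-fold higher number from compound 3 to compound 4 (0.20 log units; within the scatter) is expected to be modest, possibly within the scatter, with a slightly higher number somewhat more likely. Compound 4 is estimated at 70 nM, within 15 nM to 300 nM.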

Compound 4, half-maximal effective concentration: 5500 nM
Compound 4: middle estimate off by 79-fold (1.90 log units), on the low side; the whole stated range lies below it.
By their numbers in this assay, from the lowest: compound 1; then compound 3; then compounds 2 and 4 (each within the scatter of the next).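

Exchanging ethyl for acetamido on this aromatic carbon, para to a large group, brings a 130-fold higher number from compound 3 to compound 4 (2.10 log units; beyond the scatter) in this assay and so shows that the position is sensitive to the group it carries. The change adds a hydrogen-bond donor and a hydrogen-bond acceptor, but nothing available explains the loss. With only ethyl and acetamido compared here, the compounds shown leave open whether the amide carbonyl or the amide hydrogen matters. They also leave open how a simple amine, a methoxy group or a longer propyl chain would fare at this position.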